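Moving from pyridinyl to sulfamoylphenyl on the amide

The source may report more compounds than this note shows. Statements on the series, on what has been measured and on what is new or still open speak of the compounds shown alone.

Measured so far:
- compound 1 `CC(C)n1ncc2c(C(=O)Nc3ccc(F)c(S(N)(=O)=O)c3)cc(-c3cccs3)nc21`: 50000 nM
- compound 2 `CC(C)n1ncc2c(C(=O)Nc3cccnc3)cc(-c3cccs3)nc21`: > 200000 nM

Of the compounds shown here, two sharing one core have been tested in an ADME assay on LLC-MK2 cells (Macaca mulatta) for cytotoxicity, read by spectrophotometry and crystal violet staining, with a stated time of 4 days; on this read-out higher numbers stand for lower toxicity in this test and lower numbers for higher toxicity in this test. Compound 1 gives 50000 nM. On these data alone, compound 2 reaches only the limit of this assay, giving > 200000 nM, which is a limit and not a number, so its true value is unknown beyond (the limit of > 200000 nM in this assay, at which 1 of the 2 values shown sits). Compound 3 `CC(C)n1ncc2c(C(=O)Nc3cccc(S(N)(=O)=O)c3)cc(-c3cccs3)nc21` has not yet been measured in this assay. It differs from compound 2 in one place: 3-sulfamoylphenyl in place of pyridin-3-yl on an amide-type nitrogen. Going by the values given here, with no measured step to lean on, the expectation rests on compound 1, which gives 50000 nM and carries the same kind of sulfamoylphenyl group. Compound 3 is therefore expected to give roughly 60000 nM, with a likely range from 20000 nM to 200000 nM. That estimate means an expected step of an at least 3.3-fold lower number from compound 2 to compound 3 (0.52 log units; beyond the scatter), pointing towards higher toxicity, beyond the usual scatter.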

Compound 3, half-maximal cytotoxic concentration: 25000 nM
Estimate against measurement, compound 3: 2.4-fold (0.38 log units) above; low and high end bracket the measured number.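

In this assay, 3-sulfamoylphenyl in place of pyridin-3-yl on the amide-type nitrogen brings an at least 8.0-fold lower number from compound 2 to compound 3 (0.90 log units; beyond the scatter), the first step measured at this position, and it points towards higher toxicity in this test. Compound 2 stands at a limit and not at a number, so this step has a lower bound and no exact size: the limit of > 200000 nM in this assay, at which 1 of the 3 values shown sits. Hydrogen in place of fluoro on an aromatic carbon gives a 2.0-fold lower number from compound 1 to compound 3 (0.30 log units; within the scatter), so this fluoro makes no difference that can be told from the scatter.

Still open, on these data alone, is whether the step comes from the sulfamoyl group or from the change of ring, which a plain phenyl on the amide-type nitrogen would help to separate. As far as these compounds go, how a phenyl carrying a carboxylic acid or an amine would read in this assay also remains open.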